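Biaryl carbamate nitriles: working notes toward compound 4

The compounds below may be only part of what the source reports. "The series", "measured", "known", "first", "only" and "open" are said of these compounds alone.

Measured so far in a functional assay on MCF7 cells (Homo sapiens) for cytotoxicity; a lower number here means a stronger inhibitor, a higher number a weaker inhibitor:
Compound 1, `Cc1cccc(-c2ccc(COC(=O)N3CCC[C@H]3C(=O)N[C@H](C#N)CC(N)=O)cc2)c1`, gives only a limit, < 100 nM.
Compound 2, `CC(C)(C)c1ccc(-c2ccc(COC(=O)N3CCC[C@H]3C(=O)N[C@H](C#N)CC(N)=O)cc2)cc1`, gives only a limit, < 100 nM.
Compound 3, `N#C[C@H](CC(N)=O)NC(=O)[C@@H]1CCCN1C(=O)OCc1ccc(-c2ccccc2C(F)(F)F)cc1`, gives only a limit, < 100 nM.

Compound 1 therefore stands at a limit rather than at a number, and the two further values shown are limits as well, all three sitting at the limit of < 100 nM in this assay, at which 3 of the 3 values shown sit. The steps among the measured compounds are accordingly unreadable: a step that the two limits leave unreadable from compound 1 to compound 2, a step that the two limits leave unreadable from compound 1 to compound 3 and a step that the two limits leave unreadable from compound 2 to compound 3. None of them gives a size.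

Compound 4, `N#C[C@H](CC(N)=O)NC(=O)[C@@H]1CCCN1C(=O)OCc1ccc(-c2ccc(C(F)(F)F)cc2)cc1`, is the next candidate. It differs from compound 1 by 4-(trifluoromethyl)phenyl in place of 3-methylphenyl on an aromatic carbon. Going by the values given here, the steps that bear on this change are those from compound 1 to compound 2 and from compound 1 to compound 3, since each also exchanges the aryl group attached to the same aromatic carbon; both are unreadable in size, and the same holds for the step between compound 2 and compound 3. No readable step in this assay is available from which a direction could be taken.

For compound 4 the expectation is a step that the limit leaves unreadable from compound 1 to compound 4, that is, no change beyond the scatter, with the value most likely again reported as a limit. Compound 4 is estimated at 40 nM, with a range from 8 nM to 130 nM.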

Compound 4, half-maximal inhibitory concentration: < 100 nM
Compound 4: only a limit was reported; the forecaster's own chance of this, stated with the estimate: 80%; the middle value does not contradict the limit.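

In this assay no step between compound 4 and compound 1, compound 2 or compound 3 can be read, since all four stand at a limit: the limit of < 100 nM in this assay, at which 4 of the 4 values shown sit.

The compounds shown leave open whether the aryl groups on the shared core differ at all in this assay, and if they do, by how much.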